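Extending the ester chain of compound 3

The source may hold more compounds than are shown below. What is called first, only, known or untested is meant among the compounds shown, and "the series" means these compounds.

Compound 3 (`CCCCCCCC(=O)OCC(C)(C)CC1=C(O)C(=O)c2ccccc2C1=O`) gives no exact number in an ADME assay on Vero cells (Chlorocebus sabaeus) for cytotoxicity, read by reporter gene assay, with a stated time of 4 days (a lower number here means a stronger inhibitor, a higher number a weaker inhibitor), only a limit of > 258000 nM. That places it at the limit of > 258000 nM in this assay, at which 1 of the 3 values shown sits. Compound 4 (`CCCCCCCCCC(=O)OCC(C)(C)CC1=C(O)C(=O)c2ccccc2C1=O`) differs from it by ethyl in place of hydrogen on a saturated chain carbon, seven bonds along the chain from a carbonyl carbon. Among the compounds with values here, no measured pair shows this change directly. The nearest hint comes from two compounds sharing the core: compound 1 (`CCCC(C)C(=O)NCC(C)(C)CC1=C(O)C(=O)c2ccccc2C1=O`) reads 48100 nM, and compound 2 (`CCCCCCCCCCCCCCCCCC(=O)NCC(C)(C)CC1=C(O)C(=O)c2ccccc2C1=O`), with its much longer chain, reads lower at 5760 nM. A modest move toward a lower number is therefore expected, shown as the estimated step of an at least 1.7-fold lower number from compound 3 to compound 4 (0.23 log units; that floor lies within the scatter). For compound 4 the estimated value is 150000 nM, with an expected range of 40000 nM to 300000 nM.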

Compound 4, half-maximal inhibitory concentration: 203000 nM
Beside the measured number, compound 4's estimate is 1.4-fold (0.13 log units) below it; low and high end bracket the measured number.
By their numbers in this assay, from the lowest: compound 2; then compound 1; then compound 4. At a limit, above all of these: compound 3.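

Compound 4 gives this ester series an exact number in this assay, where compound 3 offers only a limit. Ethyl in place of hydrogen at this position gives an at least 1.2-fold lower number from compound 3 to compound 4 (0.10 log units; that floor lies within the scatter), so the change is compatible with a real drop, but its true size remains unknown. The step is only a floor because compound 3 has a limit rather than an exact value: the limit of > 258000 nM in this assay, at which 1 of the 4 values shown sits.

On these data alone, whether a longer chain in place of ethyl would move the number further stays open. So does the effect of an amine or a carboxylic acid there.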